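The compounds below may be only part of what the source reports. "The series", "measured", "known", "first", "only" and "open" are said of these compounds alone.

Measured so far in a physicochemical assay for acid dissociation:
compound 1, `COc1ccc(F)cc1CNCCCNc1ccnc2cc(Cc3ccc(C#N)cc3)ccc12`; in this assay compound 1 gives 9.47
compound 2, `COc1ccc(F)cc1CNCCCNc1ccnc2cc(-c3cccc4ccccc34)ccc12`; in this assay compound 2 gives 9.47

Going by the values given here, compound 2 stands level with compound 1 at the digits printed; the one step recorded between them, no change at the digits printed from compound 1 to compound 2 (within the scatter), lies within the scatter, so the two values cannot be told apart. The substituent varied in that step is the group on the aromatic carbon of the shared core, and the read-out was indifferent to it.

Compound 3, `COc1ccc(F)cc1CNCCCNc1ccnc2cc(Oc3ccccc3OC)ccc12`, is the next member. The change from compound 2 is 2-methoxyphenoxy in place of naphthalen-1-yl on an aromatic carbon. Among the compounds with values here, the one measured step that bears on this change is the exchange at the same aromatic carbon, no change at the digits printed from compound 1 to compound 2 (within the scatter), which produced no movement beyond the scatter although it swapped two groups of quite different make-up. The present exchange sits at the same position and again leaves the rest of the structure untouched, so on the data in hand no step beyond the scatter is expected; the expected step is no change at the digits printed from compound 2 to compound 3 (within the scatter). For compound 3 the estimated value in this assay is 9.47, with a range of 9.2 to 9.75.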

Compound 3, acid dissociation constant: 9.28
Compound 3: the middle estimate sits 0.19 log units above what was measured; the range from low to high includes it.
By their numbers in this assay, from the lowest: compounds 3, 1 and 2 (each within the scatter of the next).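

In this assay the aromatic carbon of the shared core now carries a third type of group, 2-methoxyphenoxy, and the reading stays within the scatter against both earlier compounds (a number 0.19 log units lower from compound 2 to compound 3 (within the scatter); a number 0.19 log units lower from compound 1 to compound 3 (within the scatter)). Naphthalen-1-yl has only carbon and no hydrogen-bond acceptors, whereas 2-methoxyphenoxy brings oxygen, hydrogen-bond acceptors and one six-membered aromatic ring of carbon only in place of two, so the tolerance seen between the first two compounds now extends to a change of atom make-up and ring count, and the three compounds cannot be separated in this read-out. Nothing available bears on what underlies this lack of response.

From the compounds shown here alone, all three groups at this position contain aromatic rings and carry no net charge, so it remains open whether an amine or a carboxylic acid on the same carbon would also stay within the scatter. The chain on the shared core is identical across the three compounds, leaving open whether a longer chain in its place would shift the reading.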